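The source may report more compounds than this note shows. Statements on the series, on what has been measured and on what is new or still open speak of the compounds shown alone.

Measured in a functional assay on MIA PaCa-2 cells (Homo sapiens) for inhibition, read by MTT assay, with a stated time of 72 h; a higher number here means a weaker inhibitor of growth, a lower number a stronger inhibitor of growth:
- compound 1 `O=S(=O)(NCCCNCc1ccccc1Cl)c1cc(C(F)(F)F)cc(C(F)(F)F)c1` gives 11000 nM
- compound 2 `CC(C)(C)c1ccc(CNCCCNS(=O)(=O)c2cc(C(F)(F)F)cc(C(F)(F)F)c2)cc1` gives 2300 nM
- compound 3 `O=S(=O)(NCCCNCC1COc2ccccc2O1)c1cc(C(F)(F)F)cc(C(F)(F)F)c1` gives 2600 nM

Compound 3 sits second highest of the three numbers in this assay. Its nearest neighbour is compound 2, and the gap between them, a 1.1-fold higher number from compound 2 to compound 3 (0.05 log units; within the scatter), is within the scatter, so no order between compound 2 and compound 3 can be read. Compound 1 is the furthest away, and a 4.2-fold lower number from compound 1 to compound 3 (0.63 log units; beyond the scatter) lies beyond the scatter.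

Compound 4 `O=S(=O)(NCCCNCc1ccc(C(F)(F)F)cc1)c1cc(C(F)(F)F)cc(C(F)(F)F)c1` differs from compound 3 by 4-(trifluoromethyl)phenyl in place of 2,3-dihydro-1,4-benzodioxin-2-yl on a saturated chain carbon bound to an amine nitrogen; cut one bond further out, the change reads (2,3-dihydro-1,4-benzodioxin-2-yl)methyl to 4-(trifluoromethyl)benzyl.

Going by the values given here, the steps that bear on this position are a 4.8-fold lower number from compound 1 to compound 2 (0.68 log units; beyond the scatter) and a 4.2-fold lower number from compound 1 to compound 3 (0.63 log units; beyond the scatter), both modest and both away from 2-chlorophenyl, while a 1.1-fold higher number from compound 2 to compound 3 (0.05 log units; within the scatter) shows that 4-(tert-butyl)phenyl and 2,3-dihydro-1,4-benzodioxin-2-yl are indistinguishable within the scatter. A second six-membered aromatic ring of carbon only at this place, 4-(trifluoromethyl)phenyl, is therefore expected to land near compound 2 and compound 3, with no step beyond the scatter in this assay. The expected step is a 1.0-fold lower number from compound 3 to compound 4 (0.02 log units; within the scatter). Compound 4 is estimated at 2500 nM, with a range from 1000 nM to 6500 nM.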

Compound 4, concentration for 50% growth inhibition: 2500 nM
Compound 4: middle estimate and measured number agree at the digits printed; the measured number falls inside the stated range.
By their numbers in this assay, from the lowest: compounds 2, 4 and 3 (each within the scatter of the next); then compound 1.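

Within this assay, a 1.0-fold lower number from compound 3 to compound 4 (0.02 log units; within the scatter) shows that 4-(trifluoromethyl)phenyl, with 0 hydrogen-bond acceptors, cannot be told apart from 2,3-dihydro-1,4-benzodioxin-2-yl, with 2, while a 1.1-fold higher number from compound 2 to compound 4 (0.04 log units; within the scatter) shows the same for trifluoromethyl in place of tert-butyl on an aromatic carbon. With a 4.4-fold lower number from compound 1 to compound 4 (0.64 log units; beyond the scatter), a third replacement of 2-chlorophenyl gives a step beyond the scatter, so among these four compounds only compound 1 stands apart from the rest. No measurement shown here accounts for these results.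

Compound 1 differs from compound 4 in both the substituent and its place on the ring, so 4-chlorophenyl would be needed to separate the two. As far as these compounds go, the effect of a nitrile or a carboxylic acid on the aromatic ring, or of a pyridine ring in place of the benzene ring, remains open.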